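Compound 3 to compound 4: exchanging 2-chloro-4-cyanophenyl

The source may report more compounds than this note shows. Statements on the series, on what has been measured and on what is new or still open speak of the compounds shown alone.

Values in a functional assay on MCF7 cells (Homo sapiens) for antiproliferative activity, read by CellTiter-Glo, with a stated time of 5 days (a higher number here means a weaker inhibitor, a lower number a stronger inhibitor), so far:
compound 1 (`N#Cc1ccc(/C(=C(\c2ccc(/C=C/C(=O)O)cc2)c2ccc3scnc3c2)C2CCC2)c(Cl)c1`) gives 1.4 nM
compound 2 (`O=C(O)/C=C/c1ccc(/C(=C(\c2ncc(C(F)(F)F)cc2Cl)C2CCC2)c2ccc3scnc3c2)cc1`) gives 2.9 nM
compound 3 (`N#Cc1ccc(/C(=C(\c2ccc(/C=C/C(=O)O)cc2)c2ccc(-c3cn[nH]c3)cc2)C2CCC2)c(Cl)c1`) gives 2.2 nM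

Compound 3 stands within the scatter of both other compounds, as its step from the first (a 1.6-fold higher number from compound 1 to compound 3 (0.20 log units; within the scatter)) and its value close to that of compound 2 show. Compound 4 (`O=C(O)/C=C/c1ccc(/C(=C(\c2ncc(C(F)(F)F)cc2Cl)C2CCC2)c2ccc(-c3cn[nH]c3)cc2)cc1`) is compound 3 with a single exchange (3-chloro-5-(trifluoromethyl)pyridin-2-yl in place of 2-chloro-4-cyanophenyl on a double-bonded chain carbon bound to a double-bonded chain carbon and a saturated ring carbon). The same exchange has one measured precedent, on the core of compound 1 (a 2.1-fold higher number from compound 1 to compound 2 (0.32 log units; beyond the scatter)), a modest step just beyond the scatter. The 4-(1H-pyrazol-4-yl)phenyl group shared by compound 3 and compound 4 gave a step within the scatter, but a single pair cannot show that the two changes add. In this assay a modest step of similar size towards a higher number is therefore expected, close to the edge of the scatter. The expected step is (a 2.0-fold higher number from compound 3 to compound 4 (0.31 log units; beyond the scatter)). For compound 4 the estimated value is 4.5 nM within an expected range (2.2 nM to 9 nM).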

Compound 4, half-maximal inhibitory concentration: 16 nM
For compound 4 the middle estimate is 3.6-fold (0.55 log units) below the measured one, outside the stated range (above it).
By their numbers in this assay, from the lowest: compounds 1, 3 and 2 (each within the scatter of the next, the first and the last beyond it); then compound 4.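

In this assay, for the compounds shown here, the exchange of 2-chloro-4-cyanophenyl for 3-chloro-5-(trifluoromethyl)pyridin-2-yl gives a much larger step when 4-(1H-pyrazol-4-yl)phenyl is present, a 7.3-fold higher number from compound 3 to compound 4 (0.86 log units; beyond the scatter), than in its one earlier precedent: the same change on two cores in this assay, a 2.1-fold higher number (0.32 log units; beyond the scatter) from compound 1 to compound 2 and a 7.3-fold higher number (0.86 log units; beyond the scatter) from compound 3 to compound 4, 3.5-fold (0.55 log units) apart, beyond the scatter of two such steps. The other change shows the same dependence, since 4-(1H-pyrazol-4-yl)phenyl in place of 1,3-benzothiazol-5-yl gives a 5.5-fold higher number from compound 2 to compound 4 (0.74 log units; beyond the scatter) with the pyridine group present: the same change on two cores in this assay, a 1.6-fold higher number (0.20 log units; within the scatter) from compound 1 to compound 3 and a 5.5-fold higher number (0.74 log units; beyond the scatter) from compound 2 to compound 4, 3.5-fold (0.55 log units) apart, beyond the scatter of two such steps. The two exchanges therefore do not add across these four compounds, and the size of each depends on the group present at the other place.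

On these data alone, it remains open whether this dependence follows the trifluoromethyl, the ring nitrogen or the loss of the nitrile. A chlorophenyl carrying trifluoromethyl, or a chloropyridinyl carrying a nitrile, on each core would separate these.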